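Adding a Pyridin-2-yl Group to the Oxazole Ketone

The source may hold more compounds than are shown below. What is called first, only, known or untested is meant among the compounds shown, and "the series" means these compounds.

Measured so far in an assay for inhibition of Fatty-acid amide hydrolase 1 (Rattus norvegicus), using a Dixon plot; a lower number here means a stronger inhibitor, a higher number a weaker inhibitor:
Compound 1, `O=C(c1ncc(-c2ccccn2)o1)[C@H]1COc2cc(OCc3ccccc3)ccc2C1`: compound 1 gives 18 nM
Compound 2, `O=C(c1ncc(-c2ccccn2)o1)[C@@H]1COc2cc(Oc3ccccc3)ccc2C1`: compound 2 gives 27 nM
Compound 3, `O=C(c1ncco1)[C@@H]1COc2cc(OCc3ccccc3)ccc2C1`: compound 3 gives 16 nM

Compound 3 has the lowest number of the three, but its gaps to compound 1 and to compound 2 both fall within the usual scatter, so none of the three can be called the stronger inhibitor. Compound 4, `O=C(c1ncc(-c2ccccn2)o1)[C@@H]1COc2cc(OCc3ccccc3)ccc2C1`, differs from compound 3 by pyridin-2-yl in place of hydrogen on an aromatic carbon. Going by the values given here, no step between two measured compounds isolates this change, so the expectation leans on the narrow spread seen so far. In this assay the step is estimated as a 1.1-fold lower number from compound 3 to compound 4 (0.03 log units; within the scatter), that is, nothing beyond the scatter. Compound 4 is therefore expected to give 15 nM, with a range from 5 nM to 45 nM.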

Compound 4, inhibition constant: 17 nM
For compound 4 the middle estimate is 1.1-fold (0.05 log units) below the measured one, within the range that was stated.
By their numbers in this assay, from the lowest: compounds 3, 4, 1 and 2 (each within the scatter of the next).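

Pyridin-2-yl in place of hydrogen on the aromatic carbon next to the ring oxygen gives, in this assay, a 1.1-fold higher number from compound 3 to compound 4 (0.03 log units; within the scatter), so this large group shows no separation from hydrogen here. Benzyl in place of phenyl on the oxygen also stays inside the scatter, with a 1.6-fold lower number from compound 2 to compound 4 (0.20 log units; within the scatter). The stereocentre at the saturated ring carbon shows no separation either, with a 1.1-fold lower number from compound 1 to compound 4 (0.02 log units; within the scatter), and this comparison isolates configuration alone: the fact that compounds 1 and 4 differ only in the configuration as drawn

From the compounds shown here alone, whether an amine or a carboxylic acid in place of pyridin-2-yl, or a longer chain in place of benzyl, would give a step beyond the scatter stays open.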